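Replacing trifluoromethoxy with methylsulfanyl at a cytotoxicity limit

The source may report more compounds than this note shows. Statements on the series, on what has been measured and on what is new or still open speak of the compounds shown alone.

Measured so far in an ADME assay on HEK293 cells (Homo sapiens) for cytotoxicity, with a stated time of 72 h; a lower number here means that less compound is needed, a higher number that more compound is needed for the effect:
- compound 1 `Cc1cc(NC(=O)Nc2ccccc2OC(F)(F)F)c2ccccc2n1`: > 25000 nM (a limit, not a number)
- compound 2 `Cc1cc(NC(=O)Nc2ccc(F)cc2)c2ccccc2n1`: > 25000 nM (a limit, not a number)

Compound 1 stands at > 25000 nM, which is a limit of this assay and not a number. Compound 2 gives no number either, only the limit > 25000 nM. The next compound to be tested is compound 3 `CSc1ccccc1NC(=O)Nc1cc(C)nc2ccccc12`. It has methylsulfanyl in place of trifluoromethoxy on an aromatic carbon. Within the data shown here, no measured pair shows what a change at this place does, so the expectation rests on compound 1 and compound 2, which share (the limit of > 25000 nM in this assay, at which 2 of the 2 values shown sit). No step beyond the scatter is expected, and the estimated change is a number no higher from compound 1 to compound 3 (the limit leaves the size open). The result will most likely be reported as a limit again. The estimate for compound 3 is 25000 nM, with an expected range from 12000 nM to 50000 nM.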

Compound 3, half-maximal effective concentration: > 25000 nM
Compound 3: a limit, no number; the forecaster's own chance of this, stated with the estimate: 85%; the middle value lies on the limit itself.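

In this assay compound 3 gives > 25000 nM, which is a limit and not a number. Among these compounds, compound 1 also stands at a limit, so no step between compound 1 and compound 3 can be read. The compounds shown leave open what concentration of any of them would produce the effect.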